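Aryl to arylamino on the shared core

A few compounds are considered here, and "the series" means these few. Any claim that something is new, unique, unknown or untested is made for them only; others in the source may bear on it.

In a functional assay on A549 cells (Homo sapiens) for antiproliferative activity, read by MTT assay, with a stated time of 72 h (a lower number here means a stronger inhibitor, a higher number a weaker inhibitor), compound 1 (`COc1ccc(-c2c(C(=O)c3cc(OC)c(OC)c(OC)c3)sc3ccccc23)cc1`) gives 4400 nM, compound 2 (`COc1cc(C(=O)c2sc3ccccc3c2-c2ccc(SC)cc2)cc(OC)c1OC`) gives 5400 nM and compound 3 (`CCOc1ccc(-c2c(C(=O)c3cc(OC)c(OC)c(OC)c3)sc3ccccc23)cc1`) gives 3100 nM. Compound 3 is not separated from the other two: a 1.4-fold lower number from compound 1 to compound 3 (0.15 log units; within the scatter) and a 1.7-fold lower number from compound 2 to compound 3 (0.24 log units; within the scatter) both lie within the scatter.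

Compound 4 (`CCOc1ccc(Nc2c(C(=O)c3cc(OC)c(OC)c(OC)c3)sc3ccccc23)cc1`) carries (4-ethoxyphenyl)amino in place of 4-ethoxyphenyl on an aromatic carbon of the shared core: (4-ethoxyphenyl)amino in place of 4-ethoxyphenyl on an aromatic carbon. The measured steps, together with a 1.2-fold higher number from compound 1 to compound 2 (0.09 log units; within the scatter), only exchange methoxy, methylsulfanyl and ethoxy on the aromatic ring. All three stay within the scatter, and none alters the link between that ring and the core. They therefore give no direct guide to this change and no direction for it. With so little support, no step beyond the scatter is expected in this assay, though the uncertainty is wide. The expected step is a 1.2-fold lower number from compound 3 to compound 4 (0.09 log units; within the scatter). In this assay the estimate for compound 4 is 2500 nM, with an expected range of 400 nM to 9000 nM.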

Compound 4, half-maximal inhibitory concentration: 1400 nM
For compound 4 the middle estimate is 1.8-fold (0.25 log units) above the measured one; measured number inside the range.
By their numbers in this assay, from the lowest: compound 4; then compounds 3, 1 and 2 (each within the scatter of the next).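

In this assay, changing the aryl group on the shared core to an arylamino group gives steps beyond the scatter, though all modest: (a 2.2-fold lower number from compound 3 to compound 4 (0.35 log units; beyond the scatter)) with the ethoxy group kept, (a 3.1-fold lower number from compound 1 to compound 4 (0.50 log units; beyond the scatter)) against 4-methoxyphenyl and (a 3.9-fold lower number from compound 2 to compound 4 (0.59 log units; beyond the scatter)) against 4-(methylsulfanyl)phenyl. Among compounds 1 to 3, exchanging the group on the aromatic ring stayed within the scatter, so across these four compounds, only the change at the attachment to the aromatic carbon of the five-membered aromatic ring moves the number beyond it. Nothing shown accounts for this step.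

On these data alone, whether the amino hydrogen is needed remains open, and a methylamino or ether oxygen connection would test it. Also open, as far as these compounds go, is whether methoxy, methylsulfanyl or a longer alkoxy chain on the arylamino ring would stay within the scatter of compound 4.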